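This account rests on a few compounds, and the source may have more. Where it says the series, first, only, none or still open, it means among the compounds named here.

Compound 1 `O=C(Nc1ccc(F)c(-c2nc3ncc(-c4ccc(F)cc4F)cc3[nH]2)c1)N1CCCC1` carries a 2,4-difluorophenyl group on the shared core. Among the measured compounds shown here, in an ADME assay on HepG2 cells (Homo sapiens) for cytotoxicity, read by resazurin assay, with a stated time of 48 h (a lower number here means that less compound is needed, a higher number that more compound is needed for the effect), compound 1 gives 32400 nM, the only actual number here. For compound 2 `O=C(Nc1ccc(F)c(-c2nc3ncc(-c4ccc(F)nc4)cc3[nH]2)c1)N1CCCC1` this assay reports a limit, > 50000 nM, which is the limit of > 50000 nM in this assay, at which 1 of the 2 values shown sits. Compound 3 `O=C(Nc1ccc(F)c(-c2nc3ncc(-c4ccc(O)cc4)cc3[nH]2)c1)N1CCCC1` differs from compound 1 by 4-hydroxyphenyl in place of 2,4-difluorophenyl on an aromatic carbon. For the measured compounds named here, the single measured step bearing on this position, an at least 1.5-fold higher number from compound 1 to compound 2 (0.18 log units; that floor lies within the scatter), leads to an expectation for compound 3 of a 1.2-fold higher number from compound 1 to compound 3 (0.09 log units; within the scatter), nothing beyond the scatter. Compound 3 is thus estimated at 40000 nM in this assay, with a range of 15000 nM to 100000 nM.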

Compound 3, half-maximal effective concentration: > 50000 nM
Compound 3: no number, only a limit; the forecaster's own chance of this, stated with the estimate: 45%; middle value at least 1.2-fold (0.09 log units) away from the limit.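

In this assay, compound 3, like compound 2, returns a limit and not a number: the limit of > 50000 nM in this assay, at which 2 of the 3 values shown sit.

Replacing 2,4-difluorophenyl with 4-hydroxyphenyl gives an at least 1.5-fold higher number from compound 1 to compound 3 (0.18 log units; that floor lies within the scatter), so a second replacement at this position, this time with a carbon-only ring bearing a hydrogen-bond donor, also reaches the limit. The step between the two limits cannot be read, so the two entering groups cannot be ranked.

As far as these compounds go, the actual numbers behind the limits of compound 2 and compound 3 stay open. So does whether a different group here, such as 4-aminophenyl or 4-carboxyphenyl, would give a measurable value.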